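Hydroxy for chloro on the thioether aryl: expected tolerability

This account rests on a few compounds, and the source may have more. Where it says the series, first, only, none or still open, it means among the compounds named here.

In an ADME assay on HEL cells (Homo sapiens) for cytotoxicity, with a stated time of 3 days (a lower number here means that less compound is tolerated, a higher number that more compound is tolerated), compound 1, `Cc1cc(-n2ccc3ccccc32)c2ncc(CSCCc3ccccc3)n2c1`, gives > 100 ug/mL, which is a limit of the assay and not a number. Compound 2, `Cc1cc(Sc2ccc(Cl)cc2)c2ncc(CSCCc3ccccc3)n2c1`, gives 100 ug/mL in this assay.

Compound 2 thus holds the only number shown; the one other value is a limit. The step of a number no higher from compound 1 to compound 2 (the limit leaves the size open) cannot be sized, since the limit of > 100 ug/mL in this assay, at which 1 of the 2 values shown sits, caps the first value. Compound 3, `Cc1cc(Sc2ccc(O)cc2)c2ncc(CSCCc3ccccc3)n2c1`, differs from compound 2 by hydroxy in place of chloro on an aromatic carbon. Among the measured compounds shown here, no measured step touches this change; the single measured step, with its open size, bears on it only in showing that both measured compounds are tolerated at the top of the range in this assay. The step from compound 2 to compound 3 is therefore expected to be no change at the digits printed from compound 2 to compound 3 (within the scatter), nothing beyond the scatter in either direction. Compound 3 is expected to give about 100 ug/mL, between 50 ug/mL and 200 ug/mL, in this assay.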

Compound 3, half-maximal cytotoxic concentration: 79 ug/mL
For compound 3 the middle estimate is 1.3-fold (0.10 log units) above the measured one, and the stated range covers the measured number.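

In this assay, hydroxy in place of chloro, on an aromatic carbon para to a large group, gives a 1.3-fold lower number from compound 2 to compound 3 (0.10 log units; within the scatter), so this position accepts a group with a hydrogen-bond donor and acceptor without a step beyond the scatter. The (4-hydroxyphenyl)sulfanyl group set against 1H-indol-1-yl gives an at least 1.2-fold lower number from compound 1 to compound 3 (0.10 log units; that floor lies within the scatter), which is a floor and not a size. The value of compound 1 is a limit and not a number: the limit of > 100 ug/mL in this assay, at which 1 of the 3 values shown sits.

Still open, from the compounds shown here alone, is whether a group of another kind at this place, such as an amine or a carboxylic acid, would also stay within the scatter of compound 2 in this assay. Also open, going by these compounds, is whether a longer chain in place of the thioether arm on the shared core would shift the number.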